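The source may hold more compounds than are shown below. What is called first, only, known or untested is meant among the compounds shown, and "the series" means these compounds.

Working notes on the series.

Compound 1 `COc1ccccc1-n1cc(COc2ccc3c(c2)CCC3)nn1` and compound 2 `Cc1ccc(-n2cc(COc3ccc4c(c3)CCC4)nn2)c(C)c1` share one core and differ only in the group on the aromatic nitrogen. In an ADME assay on HEK293 cells (Homo sapiens) for inhibition, read by MTT assay, with a stated time of 48 h, tested at 25 uM (a higher number here means more inhibition at the concentration tested (going by the name of the read-out), a lower number less inhibition), compound 1 gives 19.8%, and in this assay compound 2 gives 19.9%. The step of a number 0.1 percentage points higher from compound 1 to compound 2 (within the scatter) shows that the swap of one aryl group for another on that nitrogen leaves the read-out essentially where it was. On the two numbers shown, compound 2 sits level with compound 1, the gap between them falling within the scatter, so no order between the two can be claimed.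

Compound 3 `c1ccc(-n2cc(COc3ccc4c(c3)CCC4)nn2)cc1` is not yet measured. The change from compound 2 to compound 3 is phenyl in place of 2,4-dimethylphenyl on an aromatic nitrogen. Among the compounds with values here, the one step that bears on it, from compound 1 to compound 2, also altered only the aryl group on the aromatic nitrogen and stayed within the scatter. Because a number 0.1 percentage points higher from compound 1 to compound 2 (within the scatter) was flat, the expected step in this assay is a number 0.1 percentage points higher from compound 2 to compound 3 (within the scatter), with no shift beyond the scatter. Compound 3 is therefore estimated at 20%, with a range from 8% to 32%.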

Compound 3, a percentage reported as inhibition, at one concentration (the size of the read-out at that concentration, not a potency): 23.4%
The estimate for compound 3 lay 3.4 percentage points below the measured number; low and high end bracket the measured number.
By their numbers in this assay, from the lowest: compounds 1, 2 and 3 (each within the scatter of the next).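

The third compound extends the comparison to the bare phenyl group on the aromatic nitrogen in this assay: a number 3.5 percentage points higher from compound 2 to compound 3 (within the scatter) comes with the loss of both methyl groups of 2,4-dimethylphenyl, and a number 3.6 percentage points higher from compound 1 to compound 3 (within the scatter) comes with hydrogen in place of methoxy on an aromatic carbon. With both steps inside the scatter, neither the methoxy group nor the two methyl groups separate from the unsubstituted phenyl at this position, so across compounds 1, 2 and 3 the aryl substitution shown has no readable effect on this read-out. No measurement at hand explains this flat picture.

On these data alone, whether an amine or a carboxylic acid on the aryl ring, or a longer alkyl chain in place of the aryl group on that nitrogen, would move the number beyond the scatter remains open. Also open, as far as these compounds go, is whether the same flat picture would hold at other concentrations, since a single-concentration percentage gives no potency.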